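Working notes: a further methoxy on the carbonyl-side ring

The compounds below may be only part of what the source reports. "The series", "measured", "known", "first", "only" and "open" are said of these compounds alone.

Measured so far in a functional assay on BT-549 cells (Homo sapiens) for cytotoxicity, read by sulforhodamine B assay, with a stated time of 48 h, tested at 100 uM; on this read-out higher numbers stand for a weaker effect at the one concentration tested and lower numbers for a stronger effect:
compound 1 `COc1ccc(C(=O)/C=C/c2cc(-c3cc(OC)c(OC)c(OC)c3)n[nH]2)cc1OC` — -75%
compound 2 `COc1cc(-c2cc(/C=C/C(=O)c3ccc(F)c(F)c3)[nH]n2)cc(OC)c1OC` — -58%

Among the measured compounds shown here, compound 1 stands lowest of the two numbers, that is as the stronger effect at the one concentration tested; the only neighbour is compound 2, and the step of a number 17 percentage points higher from compound 1 to compound 2 (beyond the scatter) lies beyond the scatter. For the measured compounds named here, nothing further has been measured, so only this single step is available for orientation.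

Compound 3 `COc1cc(C(=O)/C=C/c2cc(-c3cc(OC)c(OC)c(OC)c3)n[nH]2)cc(OC)c1OC` has not been measured. It differs from compound 1 by methoxy in place of hydrogen on an aromatic carbon, placed ortho to a methoxy group and meta to a large group on the six-membered aromatic ring of carbon only. Going by the values given here, no measured step adds or removes a single methoxy; the one known step exchanges the whole pair of methoxy groups for fluorines, and it is modest. That step does not bear directly on the present change, so no move beyond the scatter is expected in this assay, in either direction. On this basis compound 3 is estimated at -72%, with a range from -95% to -45%, the expected step being a number 3 percentage points higher from compound 1 to compound 3 (within the scatter).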

Compound 3, a percentage reported as activity, at one concentration (the size of the read-out at that concentration, not a potency): -94%
The estimate for compound 3 lay 22 percentage points above the measured number, within the range that was stated.
By their numbers in this assay, from the lowest: compound 3; then compound 1; then compound 2.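

The change adds one methoxy to the carbonyl-side ring, ortho to a methoxy group and meta to a large group, and in this assay it gives a number 19 percentage points lower from compound 1 to compound 3 (beyond the scatter). Among the compounds shown here, the earlier pair showed only that exchanging both methoxy groups for fluorines on this ring moved the number upward; this step shows that a single added methoxy on the same ring moves it beyond the scatter in the opposite direction, so the position tolerates methoxy in place of hydrogen with a stronger effect at the one concentration tested. No available data explain this step, and its cause stays unassigned.

Going by these compounds, whether the step depends on methoxy itself or on any substituent at this position remains open, since a hydroxyl, an amine or a longer chain such as ethoxy could read differently here. With only a single concentration behind each number, the series also gives no potency, so it remains open whether the order of these compounds would hold across a range of concentrations.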